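The compounds below may be only part of what the source reports. "The series", "measured", "known", "first", "only" and "open" are said of these compounds alone.

Measured so far, with the activity read in a functional assay on B16-F0 cells (Mus musculus) for inhibition, read by CCK-8 assay, with a stated time of 48 h; a higher number here means a weaker inhibitor, a lower number a stronger inhibitor:

Compound 1, `COc1cc(-c2ccnc3cc(-c4ccc(Cl)cc4)nn23)cc(OC)c1OC`, gives 4090 nM.
Compound 2, `COc1cc(-c2ccnc3c(-c4ccc(C)cc4)cnn23)cc(OC)c1OC`, reaches only the limit of this assay, > 10000 nM.
Compound 3, `COc1ccc(-c2cc3nccc(-c4cc(OC)c(OC)c(OC)c4)n3n2)cc1[N+](=O)[O-]`, likewise reaches only the limit of this assay, > 10000 nM.

Compound 3 therefore stands at the weak edge of what has been measured: its result is not a number but a limit, the same limit at which compound 2 sits, as the limit of > 10000 nM in this assay, at which 2 of the 3 values shown sit, notes. Only compound 1 has given an actual value in this assay, and that value is itself far from strong. Within the data shown here, no step between two measured compounds differing in a single place is available, so there is no direct precedent for the change now considered.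

Compound 4, `COc1ccc(-c2cc3nccc(-c4cc(OC)c(OC)c(OC)c4)n3n2)cc1F`, differs from compound 3 in one place: fluoro in place of nitro on an aromatic carbon. The nitro leaves and a fluoro enters at the same aromatic carbon, ortho to a methoxy group and meta to a large group. Among the measured compounds shown here, with no measured step to lean on, the change from compound 3 to compound 4 is expected to be modest, an at least 1.2-fold lower number from compound 3 to compound 4 (0.09 log units; that floor lies within the scatter), most likely leaving compound 4 near the weak end of this assay. Compound 4 is estimated at 8000 nM, with a plausible range from 2500 nM to 25000 nM.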

Compound 4, half-maximal inhibitory concentration: 3950 nM
Estimate against measurement, compound 4: 2.0-fold (0.31 log units) above; the measured number falls inside the stated range.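

In this assay, the aromatic carbon that carries the nitro group in compound 3 proves to be a place where a single change can be seen in the read-out: the swap to fluoro gives an at least 2.5-fold lower number from compound 3 to compound 4 (0.40 log units; beyond the scatter). Replacing 4-chlorophenyl with 3-fluoro-4-methoxyphenyl gives a 1.0-fold lower number from compound 1 to compound 4 (0.02 log units; within the scatter), so these two compounds cannot be told apart in this measurement, even though they differ in the group on that ring. The first step gives only a smallest size, and the true gap may be larger, because compound 3 has a limit and not a number: the limit of > 10000 nM in this assay, at which 2 of the 4 values shown sit.

The compounds shown leave open whether the gain belongs to fluoro itself or simply to the departure of nitro, and whether an amine, a hydroxyl group or a nitrile on the same carbon would do as well, better or worse. They also leave open how much the methoxy group on this ring contributes, and whether any change at this place can reach a much lower number than compound 4 gives, 3950 nM.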